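Removing the ethyl group from compound 2

The source may hold more compounds than are shown below. What is called first, only, known or untested is meant among the compounds shown, and "the series" means these compounds.

Compound 1 `Cc1ccccc1/C=C/C(=O)c1c(O)c2ccccc2n(Cc2ccccc2)c1=O`: 45700 nM
Compound 2 `CCn1c(=O)c(C(=O)/C=C/c2ccccc2C)c(O)c2ccccc21`: > 50000 nM

In an ADME assay on THP-1 cells (Homo sapiens) for cytotoxicity, read by MTT assay, with a stated time of 72 h (a lower number here means a stronger inhibitor, a higher number a weaker inhibitor), compound 2 gives > 50000 nM, which is a limit and not a number. It stands at the limit of > 50000 nM in this assay, at which 1 of the 2 values shown sits.

Compound 3 `Cc1ccccc1/C=C/C(=O)c1c(O)c2ccccc2[nH]c1=O` carries hydrogen in place of ethyl on an aromatic nitrogen.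

For the measured compounds named here, one measured step bears on this, the swap of phenyl for methyl on a saturated chain carbon bound to that nitrogen. It is an at least 1.0-fold higher number from compound 1 to compound 2 (0.03 log units; that floor lies within the scatter), so its floor stays within the scatter. No step beyond the scatter is therefore expected in this assay, and the expected change is a number no higher from compound 2 to compound 3 (the limit leaves the size open).

For compound 3 the estimate is 50000 nM, with an expected range from 25000 nM to 100000 nM.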

Compound 3, half-maximal inhibitory concentration: > 50000 nM
Compound 3 gave a limit, no number; the forecaster's own chance of this, stated with the estimate: 60%; the middle value lies on the limit itself.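

In this assay, compound 3 gives only a limit, not a number: > 50000 nM. Hydrogen on this nitrogen thus sits at the same limit as ethyl: the limit of > 50000 nM in this assay, at which 2 of the 3 values shown sit. Replacing benzyl with hydrogen gives an at least 1.0-fold higher number from compound 1 to compound 3 (0.03 log units; that floor lies within the scatter), while the step between the two limits cannot be read.

As far as these compounds go, what remains open is whether a longer chain ending in an amine or a carboxylic acid on this nitrogen would give a clearly lower number. From the compounds shown here alone, the true values of compound 2 and compound 3 also remain unknown.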